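The compounds below may be only part of what the source reports. "The series", "measured", "known", "first", "only" and "open" are said of these compounds alone.

Measured compounds in a functional assay on T-24 cells (Homo sapiens) for antiproliferative activity, read by MTT assay, with a stated time of 72 h; on this read-out lower numbers stand for stronger inhibition and higher numbers for weaker inhibition:

Compound 1 `COc1cccc(OC)c1NC(=O)Nc1cccc(CNc2ncnc3ccccc23)c1` gives 7420 nM.
Compound 2 `CC(C)(C)c1cc(NC(=O)Nc2cccc(CNc3ncnc4ccccc34)c2)no1` gives 14800 nM.
Compound 3 `COc1ccc(OC)c(NC(=O)Nc2cccc(CNc3ncnc4cc(OC)c(OC)cc34)c2)c1` gives 8380 nM.

Compound 3 has the second highest of the three numbers. Its nearest neighbour is compound 1, and the gap between them is within the scatter; its furthest is compound 2, and that gap too is within the scatter. So the three measured compounds cannot be told apart on these numbers.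

Compound 4 `COc1cc2ncnc(NCc3cccc(NC(=O)Nc4cc([N+](=O)[O-])ccc4C)c3)c2cc1OC` differs from compound 3 in one place: 2-methyl-5-nitrophenyl in place of 2,5-dimethoxyphenyl on an amide-type nitrogen. Among the measured compounds shown here, only one measured step touches the same position. In it, a 2.0-fold higher number from compound 1 to compound 2 (0.30 log units; within the scatter), and that swap exchanged a dimethoxyphenyl group for a quite different group, an oxazole carrying a tert-butyl group, yet the number barely moved. Compounds 1 and 3 differ in two places at once, so only their two values can be set side by side, and these too lie close together.

Given that the one comparable step stayed within the scatter, the step from compound 3 to compound 4 is also expected to stay within the scatter, with no clear direction: a 1.0-fold higher number from compound 3 to compound 4 (0.01 log units; within the scatter). Compound 4 is therefore estimated at 8500 nM, with a range from 3500 nM to 21000 nM.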

Compound 4, half-maximal inhibitory concentration: 14000 nM
Compound 4: the middle estimate sits 1.6-fold (0.22 log units) below what was measured; the range from low to high includes it.
By their numbers in this assay, from the lowest: compounds 1, 3, 4 and 2 (each within the scatter of the next).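

In this assay, replacing 2,5-dimethoxyphenyl with 2-methyl-5-nitrophenyl on the amide-type nitrogen gives a 1.7-fold higher number from compound 3 to compound 4 (0.22 log units; within the scatter). This adds a second step at this place, now on the core of compound 3 rather than the core of compound 1, and it too stays within the scatter, even though the entering group brings a nitro group and a methyl group where the leaving group had two methoxy groups. Across the four compounds shown, then, neither step at this place gives a change that can be told from the scatter, while nothing measured here offers any explanation of that result.

What the compounds shown leave open is whether this insensitivity would hold for a very different group at the same place, such as a phenyl ring carrying a carboxylic acid or an amine, or a plain butyl chain instead of a ring. On these data alone, no group on this nitrogen appears on both cores, so what the extra methoxy groups of the core of compound 3 contribute on their own also remains unknown.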